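The source may hold more compounds than are shown below. What is called first, only, known or untested is meant among the compounds shown, and "the series" means these compounds.

Measured so far in a functional assay on HCT-15 cells (Homo sapiens) for inhibition; on this read-out lower numbers stand for stronger inhibition and higher numbers for weaker inhibition:

Compound 1, `Oc1cccc(-c2cc(-c3ccccc3F)cc(-c3cccc(O)c3)n2)c1`, gives 5300 nM.
Compound 2, `Oc1ccc(-c2cc(-c3ccccc3F)cc(-c3cccc(O)c3)n2)cc1`, gives 5630 nM.
Compound 3, `Oc1cccc(-c2cc(-c3ccccc3C(F)(F)F)cc(-c3ccccc3O)n2)c1`, gives 9010 nM.

Compounds 1 and 2 share a core and differ in one place: 4-hydroxyphenyl in place of 3-hydroxyphenyl on an aromatic carbon. This change gave a 1.1-fold higher number from compound 1 to compound 2 (0.03 log units; within the scatter), so the two numbers are within the scatter of each other. Compound 3 has a different core; the difference between the two cores is not broken down here. Compound 4, `Oc1ccc(-c2cc(-c3ccccc3C(F)(F)F)cc(-c3ccccc3O)n2)cc1`, is not yet measured. It arises from compound 3 by 4-hydroxyphenyl in place of 3-hydroxyphenyl on an aromatic carbon. This is the same kind of change as from compound 1 to compound 2, but the surroundings differ: the place is meta to a 2-(trifluoromethyl)phenyl group and meta to a 2-hydroxyphenyl group rather than meta to a 2-fluorophenyl group and meta to a 3-hydroxyphenyl group. Because the earlier step was a 1.1-fold higher number from compound 1 to compound 2 (0.03 log units; within the scatter), compound 4 is expected to show a step of a 1.1-fold higher number from compound 3 to compound 4 (0.02 log units; within the scatter). Compound 4 is thus estimated at 9500 nM, in the range 5000 nM to 18000 nM.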

Compound 4, half-maximal inhibitory concentration: 8990 nM
Compound 4: the middle estimate sits 1.1-fold (0.02 log units) above what was measured; the measured number falls inside the stated range.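

In this assay, putting 4-hydroxyphenyl in place of 3-hydroxyphenyl gave a 1.0-fold lower number from compound 3 to compound 4 (0.00 log units; within the scatter). Set beside the earlier step, the change behaves alike on the two cores, with no difference beyond what repeated measurements would produce: the same change on two cores in this assay, a 1.1-fold higher number (0.03 log units; within the scatter) from compound 1 to compound 2 and a 1.0-fold lower number (0.00 log units; within the scatter) from compound 3 to compound 4, 1.1-fold (0.03 log units) apart, within the scatter of two such steps. This shows that the swap left the number unchanged within the scatter on both of these cores, but two cores are too few for a general rule, and the result does not tell why the swap makes so little difference.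

On these data alone, it remains open whether an amine or a carboxylic acid in place of the hydroxyl on this phenyl group would move the number beyond the scatter. As far as these compounds go, how the same swap behaves on any further core also remains open.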